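The compounds below may be only part of what the source reports. "The series", "measured", "known", "first", "only" and "open" are said of these compounds alone.

Compounds measured so far:
compound 1 `Cc1ccc(CNC(=O)c2cccc(C(C)Oc3ccnc(Nc4cn(C)nc4C)c3)c2)cc1` — 13400 nM
compound 2 `Cc1ccc(CNC(=O)c2cccc(C(C)Oc3ccnc(Nc4nc5ccccc5[nH]4)c3)c2)cc1` — 9400 nM

In a functional assay on NCI-H3122 cells (Homo sapiens) for antiproliferative activity, read by MTT assay, with a stated time of 48 h (a higher number here means a weaker inhibitor, a lower number a stronger inhibitor), compound 1 gives 13400 nM. Going by the values given here, compound 2 `Cc1ccc(CNC(=O)c2cccc(C(C)Oc3ccnc(Nc4nc5ccccc5[nH]4)c3)c2)cc1` gives 9400 nM in this assay, the lowest of the two numbers, though its only neighbour, compound 1, sits within the scatter: a 1.4-fold lower number from compound 1 to compound 2 (0.15 log units; within the scatter). The shared core therefore gives numbers in the same region whichever of these two groups sits on the nitrogen on the aromatic ring.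

Compound 3 `COc1cc(Nc2cc(OC(C)c3cccc(C(=O)NCc4ccc(C)cc4)c3)ccn2)cc(OC)c1OC` has not yet been measured in this assay. It differs from compound 2 in one place: 3,4,5-trimethoxyphenyl in place of 1H-benzimidazol-2-yl on a nitrogen on an aromatic ring. Among the compounds with values here, the only measured step that bears on this position is the one from compound 1 to compound 2, which exchanged one substituent on that nitrogen for another and stayed within the scatter. Nothing measured here shows what a trimethoxyphenyl group does at this place, so the expectation rests on that single, flat step. Compound 3 is therefore expected to show no step beyond the scatter, a 1.2-fold lower number from compound 2 to compound 3 (0.07 log units; within the scatter), with an estimate of 8000 nM and a range from 2500 nM to 25000 nM.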

Compound 3, half-maximal inhibitory concentration: 7800 nM
Compound 3: middle estimate off by 1.0-fold (0.01 log units), on the high side, within the range that was stated.
By their numbers in this assay, from the lowest: compounds 3, 2 and 1 (each within the scatter of the next).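

In this assay, 3,4,5-trimethoxyphenyl in place of 1H-benzimidazol-2-yl on the nitrogen on an aromatic ring gives a 1.2-fold lower number from compound 2 to compound 3 (0.08 log units; within the scatter), and the same group in place of 1,3-dimethyl-1H-pyrazol-4-yl gives a 1.7-fold lower number from compound 1 to compound 3 (0.24 log units; within the scatter). The earlier pair left open whether this flat result would hold for a group without ring nitrogen, and compound 3 shows that it does: a six-membered aromatic ring of carbon only, with three methoxy groups, stays within the scatter of both other compounds, and the loss of the hydrogen-bond donor of the 1H-benzimidazol-2-yl group in compound 2 brings no step beyond the scatter. No available measurement bears on why these three groups give numbers so close to one another.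

Going by these compounds, all three groups on this nitrogen are aromatic, so it remains open whether a saturated ring such as piperidine, an open chain such as butyl, or a group carrying a carboxylic acid would give a step beyond the scatter. The rest of the structure is also the same in all three compounds, so these numbers cannot show whether a change elsewhere on the shared core would matter more than one at this nitrogen.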